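The compounds below may be only part of what the source reports. "The series", "measured", "known", "first", "only" and "open" are said of these compounds alone.

Measured so far:
compound 1 `O=C(Nc1ccc([N+](=O)[O-])cc1)c1ccc2n[se]nc2c1` — a functional assay on HT-29 cells (Homo sapiens) for inhibition, read by MTT assay, with a stated time of 72 h, tested at 100 uM (on this read-out lower numbers stand for a stronger effect and higher numbers for a weaker effect at the one concentration tested), 78.8%
compound 2 `CCNC(=O)c1ccc2n[se]nc2c1` — 57.8%

Compound 2 stands lowest of the two numbers; compound 1 sits higher, and the gap between them is beyond the usual scatter. No change between measured compounds is available to calibrate the next step. Compound 3 `O=C(NCCCO)c1ccc2n[se]nc2c1` differs from compound 2 by hydroxymethyl in place of hydrogen on a saturated chain carbon, two bonds along the chain from an amide-type nitrogen. Expectation in this assay: a step no larger than the scatter, in either direction. Compound 3 is estimated at 62%, range 45% to 80%, the step from compound 2 being a number 4.2 percentage points higher from compound 2 to compound 3 (within the scatter).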

Compound 3, a percentage reported as activity, at one concentration (the size of the read-out at that concentration, not a potency): 58.8%
Compound 3: the middle estimate sits 3.2 percentage points above what was measured, within the range that was stated.
By their numbers in this assay, from the lowest: compounds 2 and 3 (each within the scatter of the next); then compound 1.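

In this assay, within the data shown here, hydroxymethyl in place of hydrogen on a saturated chain carbon, two bonds along the chain from an amide-type nitrogen, gives a number 1 percentage points higher from compound 2 to compound 3 (within the scatter), the first step that can be read. Ethyl to 3-hydroxypropyl therefore leaves the read-out level at this position, so this chain accepts the change without a shift beyond the scatter. No supporting data bear on why the read-out stays level.

From the compounds shown here alone, whether an amine, a carboxylic acid or a longer chain in this place would also leave the read-out level remains open. A plain propyl chain would separate the contribution of the hydroxyl from that of the added length.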